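Trading 4-nitrophenyl for 3-fluorophenyl

A few compounds are considered here, and "the series" means these few. Any claim that something is new, unique, unknown or untested is made for them only; others in the source may bear on it.

In a functional assay on SK-OV-3 cells (Homo sapiens) for cytotoxicity, read by spectrophotometry, with a stated time of 72 h (a lower number here means a stronger inhibitor, a higher number a weaker inhibitor), compound 1 (`COc1ccc(-c2cccc(=O)n2-c2cc(OC)c(OC)c(OC)c2)cc1O`) gives only a limit of the assay, not a number (< 10 nM). Compound 2 (`COc1ccc(-c2cccc(=O)n2-c2cc(OC)c(OC)c(OC)c2)cc1`) likewise gives only a limit (< 10 nM). Going by the values given here, compound 3 (`COc1cc(-n2c(-c3ccc([N+](=O)[O-])cc3)cccc2=O)cc(OC)c1OC`) has the one true number (201 nM), and it is the highest of the three. Compound 4 (`COc1cc(-n2c(-c3cccc(F)c3)cccc2=O)cc(OC)c1OC`) carries 3-fluorophenyl in place of 4-nitrophenyl on an aromatic carbon. Two measured steps bring 4-nitrophenyl onto that carbon. One is large (an at least 20-fold higher number from compound 1 to compound 3 (1.30 log units; beyond the scatter)) and so is the other (an at least 20-fold higher number from compound 2 to compound 3 (1.30 log units; beyond the scatter)), so losing that group should lower the number. The drop is expected to be partial, since 3-fluorophenyl matches neither group that 4-nitrophenyl replaced in those steps. The expected change in this assay is moderate (a 2.9-fold lower number from compound 3 to compound 4 (0.46 log units; beyond the scatter)). Compound 4 is estimated at 70 nM (expected range 15 nM to 300 nM).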

Compound 4, half-maximal inhibitory concentration: 472 nM
Compound 4: middle estimate off by 6.7-fold (0.83 log units), on the low side; measured number above the stated range.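

Swapping one group for the other at this carbon brings no gain, a 2.3-fold higher number from compound 3 to compound 4 (0.37 log units; beyond the scatter), so the high number is not tied to 4-nitrophenyl alone. The groups carried by the two strongest compounds stay far ahead of 3-fluorophenyl, an at least 47-fold higher number from compound 2 to compound 4 (1.67 log units; beyond the scatter) and an at least 47-fold higher number from compound 1 to compound 4 (1.67 log units; beyond the scatter). Those two steps give only a minimum size, since each starts from a limit of the assay: the limit of < 10 nM in this assay, at which 2 of the 4 values shown sit.

Still open, as far as these compounds go, is whether an amine or an ethoxy group on this phenyl ring would keep the number as low as methoxy does. From the compounds shown here alone, the step between compound 1 and compound 2 cannot be read, so the effect of the hydroxy group also stays unknown.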